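Benzyl ether on the side-chain oxygen: compound 4

A few compounds are considered here, and "the series" means these few. Any claim that something is new, unique, unknown or untested is made for them only; others in the source may bear on it.

Compound 1 `COc1ccc(C(O)C2OC(=O)c3c(OC)cc(OC)cc32)cc1` carries a methoxy group on the aromatic ring of the side chain. In a functional assay on RAW264.7 cells (Mus musculus) for inhibition, read by Griess assay, with stated times of 1 h and 24 h (on this read-out lower numbers stand for stronger inhibition and higher numbers for weaker inhibition), compound 1 reaches only (the limit of > 10000 nM in this assay, at which 1 of the 3 values shown sits), so its entry > 10000 nM is a limit of the assay and not a number. Compound 2 `CCCCCCOc1ccc(C(O)C2OC(=O)c3c(OC)cc(OC)cc32)cc1` gives 5360 nM in this assay, and compound 3 `COCCCCOc1ccc(C(O)C2OC(=O)c3c(OC)cc(OC)cc32)cc1` gives 8210 nM. The steps of an at least 1.8-fold lower number from compound 1 to compound 2 (0.27 log units; that floor lies within the scatter) and an at least 1.2-fold lower number from compound 1 to compound 3 (0.08 log units; that floor lies within the scatter) point the same way: a larger group on this oxygen lowers the number, though only to the edge of the scatter. Compound 4 `COc1cc(OC)c2c(c1)C(C(O)c1ccc(OCc3ccc(C)cc3)cc1)OC2=O` differs from compound 1 by 4-methylphenyl in place of hydrogen on a saturated chain carbon bound to an oxygen on an aromatic ring, again a larger group at the same place. A step like an at least 2.5-fold lower number from compound 1 to compound 4 (0.39 log units; beyond the scatter) is therefore expected. Compound 4 is estimated at 4000 nM, within a range from 1500 nM to 12000 nM.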

Compound 4, half-maximal inhibitory concentration: 3120 nM
Beside the measured number, compound 4's estimate is 1.3-fold (0.11 log units) above it; the measured number falls inside the stated range.
By their numbers in this assay, from the lowest: compounds 4, 2 and 3 (each within the scatter of the next, the first and the last beyond it). At a limit, above all of these: compound 1.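

In this assay, for the compounds shown here, the step of an at least 3.2-fold lower number from compound 1 to compound 4 (0.50 log units; beyond the scatter) is the only one out of compound 1 that clears the scatter. Compound 1 holds a limit of the assay and not a number: the limit of > 10000 nM in this assay, at which 1 of the 4 values shown sits.

Among the larger groups on this oxygen, the step of a 2.6-fold lower number from compound 3 to compound 4 (0.42 log units; beyond the scatter) separates 4-methylphenyl from 3-methoxypropyl, while the step of a 1.7-fold lower number from compound 2 to compound 4 (0.24 log units; within the scatter) does not separate it from pentyl. On these data alone, whether the aromatic ring itself matters, or only the size of the group, stays open. So does the effect of an amine or a carboxylic acid at the end of the chain on this oxygen.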